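Extending the ester chain of compound 3

This account rests on a few compounds, and the source may have more. Where it says the series, first, only, none or still open, it means among the compounds named here.

Measured so far:
Compound 1 `CCCOC(=O)C1=C(C)NC(=S)NC1c1ccco1`: 1%
Compound 2 `CCCOC(=O)C1=C(C)NC(=S)NC1c1cccs1`: 7%
Compound 3 `COC(=O)C1=C(C)NC(=S)NC1c1ccsc1`: 3%

In an assay on membranes from CHO cells for displacement of a labelled ligand from adenosine receptor A1 (Homo sapiens), read by scintillation counting, with a stated time of 60 min, tested at 1 uM (on this read-out higher numbers stand for more inhibition at the one concentration tested (going by the name of the read-out) and lower numbers for less inhibition), compound 3 gives 3%, the second highest of three numbers, yet all three lie within the scatter of one another; its nearest neighbour is compound 1 and its furthest is compound 2. Among the compounds with values here, the only measured step, a number 6 percentage points higher from compound 1 to compound 2 (within the scatter), concerns a ring swap, not the ester. Compound 4 `CCCOC(=O)C1=C(C)NC(=S)NC1c1ccsc1` differs from compound 3 by ethyl in place of hydrogen on a saturated chain carbon bound to an oxygen next to a carbonyl group, which read one bond further out is methoxycarbonyl to propoxycarbonyl. Within the data shown here, no measured step bears on this change, so no shift beyond the scatter is expected in this assay. Compound 4 is therefore estimated at 4%, between -5% and 13%, an expected step of a number 1 percentage points higher from compound 3 to compound 4 (within the scatter).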

Compound 4, a percentage reported as inhibition, at one concentration (the size of the read-out at that concentration, not a potency): 5%
The estimate for compound 4 lay 1 percentage points below the measured number, and the stated range covers the measured number.
By their numbers in this assay, from the lowest: compounds 1, 3, 4 and 2 (each within the scatter of the next).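

In this assay, within the data shown here, the change from methoxycarbonyl to propoxycarbonyl gives a number 2 percentage points higher from compound 3 to compound 4 (within the scatter) and so offers the first direct reading at this ester position: the added ethyl leaves no shift that can be told from scatter. The ring changes on the saturated ring carbon read the same way, with a number 2 percentage points lower from compound 2 to compound 4 (within the scatter) and a number 4 percentage points higher from compound 1 to compound 4 (within the scatter) in this series. No evidence is at hand to explain these small differences. Still open, from the compounds shown here alone, is whether a longer chain, an amine or a carboxylic acid at this ester position would move the number beyond the scatter.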